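A Chloro Step on a Compound Already at the Limit

The source may hold more compounds than are shown below. What is called first, only, known or untested is meant among the compounds shown, and "the series" means these compounds.

Compound 3 `CC(C)=CCOc1cccc(Nc2ncccn2)c1` is the analogue of compound 1 `CC(C)=CCOc1cccc(Nc2nccs2)c1` that carries a pyrimidin-2-yl in place of 1,3-thiazol-2-yl on a nitrogen on an aromatic ring. In a functional assay on MT2 cells (Homo sapiens) for cytotoxicity, read by MTT assay (a higher number here means that more compound is tolerated, a lower number that less compound is tolerated), compound 1 gives 23000 nM. For compound 3 in this assay only a limit is reported, > 100000 nM, which is the limit of > 100000 nM in this assay, at which 1 of the 3 values shown sits. The change amounts to an at least 4.3-fold higher number from compound 1 to compound 3 (0.63 log units; beyond the scatter). Among the three numbers shown, compound 3 is the one sitting at the limit.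

Compound 4 `CC(C)=CCOc1cc(Nc2ncccn2)ccc1Cl` differs from compound 3 by chloro in place of hydrogen on an aromatic carbon. The same change has been measured once: compound 2 `CC(C)=CCOc1cc(Nc2nccs2)ccc1Cl` gives 26000 nM in this assay, so that a 1.1-fold higher number from compound 1 to compound 2 (0.05 log units; within the scatter). Going by the values given here, no measured step shows this chloro entering when the pyrimidin-2-yl is already present.

Because a 1.1-fold higher number from compound 1 to compound 2 (0.05 log units; within the scatter) stayed within the scatter, the step is expected to be a step that the limit leaves unreadable from compound 3 to compound 4, with the value most likely again only a limit. Compound 4 is therefore estimated at 150000 nM, ranging from 60000 nM to 400000 nM.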

Compound 4, half-maximal cytotoxic concentration: 2500 nM
Estimate against measurement, compound 4: 60-fold (1.78 log units) above; measured number below the stated range.
By their numbers in this assay, from the lowest: compound 4; then compounds 1 and 2 (each within the scatter of the next). At a limit, above all of these: compound 3.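

In this assay, the chloro ortho to the (3-methylbut-2-en-1-yl)oxy group does not act alike on the two cores, since with the pyrimidin-2-yl present it gives an at least 40-fold lower number from compound 3 to compound 4 (1.60 log units; beyond the scatter), and the change therefore depends on the group on the nitrogen: the same change on two cores in this assay, a 1.1-fold higher number (0.05 log units; within the scatter) from compound 1 to compound 2 and an at least 40-fold lower number (1.60 log units; beyond the scatter) from compound 3 to compound 4, at least 45-fold (1.65 log units) apart, beyond the scatter of two such steps. The exchange of 1,3-thiazol-2-yl for pyrimidin-2-yl also changes direction once the chloro is present, giving a 10-fold lower number from compound 2 to compound 4 (1.02 log units; beyond the scatter), opposite to the step without the chloro: the same change on two cores in this assay, an at least 4.3-fold higher number (0.63 log units; beyond the scatter) from compound 1 to compound 3 and a 10-fold lower number (1.02 log units; beyond the scatter) from compound 2 to compound 4, at least 45-fold (1.65 log units) apart, beyond the scatter of two such steps. For compound 3, the value of > 100000 nM is a limit of the assay.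

The compounds shown leave open whether this drop is particular to chloro or would also follow a bromo, a methyl or an amine at the same place on the core of compound 3. They also do not tell how far beyond its limit compound 3 lies.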